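Chloro to fluoro on the shared core of compound 3

The source may hold more compounds than are shown below. What is called first, only, known or untested is meant among the compounds shown, and "the series" means these compounds.

Three measured compounds share one core. Compound 1 `O=C(CSc1nnc(-c2ccncc2)n1-c1ccccc1)N/N=C/c1ccc([N+](=O)[O-])cc1` gives 10200 nM in a functional assay on HCT-116 cells (Homo sapiens) for inhibition, read by MTT assay, with a stated time of 48 h; a lower number here means a stronger inhibitor, a higher number a weaker inhibitor. Compound 2 `O=C(CSc1nnc(-c2ccncc2)n1-c1ccccc1)N/N=C/c1ccc(Br)cc1` gives 4500 nM in this assay, and compound 3 `O=C(CSc1nnc(-c2ccncc2)n1-c1ccccc1)N/N=C/c1ccc(Cl)cc1` gives 5740 nM. Compound 3 thus holds the second highest of the three numbers, with compound 2 nearest and compound 1 furthest, both within the scatter. The halogen-for-nitro steps read a 2.3-fold lower number from compound 1 to compound 2 (0.36 log units; beyond the scatter) and a 1.8-fold lower number from compound 1 to compound 3 (0.25 log units; within the scatter); the halogen-for-halogen step reads a 1.3-fold higher number from compound 2 to compound 3 (0.11 log units; within the scatter).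

Compound 4 `O=C(CSc1nnc(-c2ccncc2)n1-c1ccccc1)N/N=C/c1ccc(F)cc1` differs from compound 3 by fluoro in place of chloro on an aromatic carbon. Among the measured compounds shown here, the one step that bears on it directly, from bromo to chloro, stayed within the scatter, and the two halogen-for-nitro steps were modest at most. Nothing here separates one halogen from another beyond the scatter. For compound 4 the expected step is a 1.1-fold higher number from compound 3 to compound 4 (0.05 log units; within the scatter), that is, no step beyond the scatter. Compound 4 is therefore estimated at 6500 nM in this assay. The expected range for compound 4 runs from 3000 nM to 14000 nM.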

Compound 4, half-maximal inhibitory concentration: 7040 nM
Estimate against measurement, compound 4: 1.1-fold (0.03 log units) below; measured number inside the range.
By their numbers in this assay, from the lowest: compounds 2, 3, 4 and 1 (each within the scatter of the next, the first and the last beyond it).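

In this assay the position para to a large group now carries three halogens, and fluoro reads a 1.2-fold higher number from compound 3 to compound 4 (0.09 log units; within the scatter) and a 1.6-fold higher number from compound 2 to compound 4 (0.19 log units; within the scatter), so chloro, bromo and fluoro are not separated here. Against nitro, fluoro reads a 1.4-fold lower number from compound 1 to compound 4 (0.16 log units; within the scatter), which leaves compound 2 as the only halogen compound set apart from compound 1 beyond the scatter. No measurement at hand accounts for these numbers.

Open, from the compounds shown here alone, is whether a group other than a halogen or nitro, such as an amine, a carboxylic acid or a methoxy group, would move the number at this position beyond the scatter. Also open, going by these compounds, is whether plain hydrogen here would read apart from the halogens on the shared core.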